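The source may report more compounds than this note shows. Statements on the series, on what has been measured and on what is new or still open speak of the compounds shown alone.

The compounds here share one core and differ in the group on a nitrogen on an aromatic ring. In an ADME assay on A549 cells (Homo sapiens) for cytotoxicity, read by LDH release, with a stated time of 15 h (on this read-out lower numbers stand for higher toxicity in this test and higher numbers for lower toxicity in this test), compound 1 `CC1(Nc2ccc(NC(=O)c3cc(Cl)ccc3O)c(Cl)c2)CCCCC1` gives 86500 nM, and compound 2 `O=C(Nc1ccc(NCC2CCCC2)cc1Cl)c1cc(Cl)ccc1O` gives 141000 nM. Compound 3 `CC(=O)Nc1ccc(NC(=O)c2cc(Cl)ccc2O)c(Cl)c1` has no number to stand on, since its entry reads "not determined" (no result reported). Going by these compounds, its place in this assay therefore stays open, and the move to compound 4 `O=C(Nc1ccc(NCc2ccco2)cc1Cl)c1cc(Cl)ccc1O` cannot be sized from it.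

The change itself is (furan-2-yl)methyl in place of acetyl on a nitrogen on an aromatic ring. Put simply, (furan-2-yl)methyl comes in place of acetyl on that nitrogen. Going by the values given here, only one measured step touches this nitrogen: a 1.6-fold higher number from compound 1 to compound 2 (0.21 log units; within the scatter). That step lies within the scatter, but it is a single pair, and neither of its compounds carries furan or acetyl, so it is a thin guide.

Compound 4 has a ring held on a methyl, as compound 2 has in cyclopentylmethyl, so the estimate leans on compound 2 at 141000 nM and on compound 1 at 86500 nM. No direction can be drawn from compound 3, and no shift beyond the scatter from that pair is expected. In this assay compound 4 is expected at about 105000 nM, with an estimated range from 45000 nM to 220000 nM.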

Compound 4, half-maximal cytotoxic concentration: 76300 nM
Compound 4: middle estimate off by 1.4-fold (0.14 log units), on the high side; the range from low to high includes it.
By their numbers in this assay, from the lowest: compounds 4, 1 and 2 (each within the scatter of the next).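

In this assay, furan-2-yl in place of cyclopentyl on the saturated chain carbon gives a 1.8-fold lower number from compound 2 to compound 4 (0.27 log units; within the scatter), and (furan-2-yl)methyl in place of 1-methylcyclohexyl gives a 1.1-fold lower number from compound 1 to compound 4 (0.05 log units; within the scatter). This nitrogen has now carried a five-membered aromatic ring as well as two saturated carbon rings, and compounds 1, 2 and 4 all remain within the scatter of one another, so none of these three groups can be separated from the others in this test. No measurement available here offers an explanation for this close agreement.

Going by these compounds, the step from acetyl to (furan-2-yl)methyl cannot be read, since compound 3 has no reported result, and so it remains unknown whether a carbonyl-bearing group on this nitrogen would fall with the other three. On these data alone, it also remains open whether a quite different group there, such as a chain ending in an amine or a carboxylic acid, would move the number beyond the scatter.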